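The source may hold more compounds than are shown below. What is called first, only, known or untested is meant among the compounds shown, and "the series" means these compounds.

Of the compounds shown here, two have been measured in an assay on CHO-K1 cells for displacement of a labelled ligand from prostaglandin E2 receptor EP1 subtype (Homo sapiens); on this read-out lower numbers stand for stronger inhibition and higher numbers for weaker inhibition. Compound 1 `Cc1cc(C(=O)NCc2ccccc2)nn1Cc1cc(Cl)ccc1OCc1ccccc1` gives 39.8 nM, the lower of the two numbers. Compound 2 `Cc1cc(C(=O)NN2CCOCC2)nn1Cc1cc(Cl)ccc1OCC(C)C` gives 251 nM, a gap beyond the usual scatter; the two differ in more than one place, so nothing ties that gap to a single change. Compound 3 `Cc1cc(NC(=O)C2CCOC2)nn1Cc1cc(Cl)ccc1OCc1ccccc1` is not yet measured and differs from compound 1 in one place: ((oxolan-3-yl)carbonyl)amino in place of benzylcarbamoyl on an aromatic carbon. Among the measured compounds shown here, no measured pair shows this change alone. A weakening step is expected, a 4.0-fold higher number from compound 1 to compound 3 (0.60 log units; beyond the scatter). Compound 3 is estimated at 160 nM, within a range from 50 nM to 500 nM.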

Compound 3, half-maximal inhibitory concentration: 39.8 nM
Compound 3: middle estimate off by 4.0-fold (0.60 log units), on the high side; measured number outside the range, below it.
By their numbers in this assay, from the lowest: compounds 1 and 3 (each within the scatter of the next); then compound 2.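

In this assay, ((oxolan-3-yl)carbonyl)amino in place of benzylcarbamoyl on this aromatic carbon gives no change at the digits printed from compound 1 to compound 3 (within the scatter). This position can therefore lose the six-membered aromatic ring of the benzyl group, and take a five-membered non-aromatic ring instead, with no loss in this read-out. Nothing measured here explains this outcome. Going by these compounds, the ring and the direction of the amide changed together, so their separate contributions remain open. On these data alone, whether a simple amine or a carboxylic acid on this carbon would fare as well also remains open.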